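The compounds below may be only part of what the source reports. "The series", "measured", "known", "first", "only" and "open" are said of these compounds alone.

Measured compounds in a functional assay on MDA-MB-231 cells (Homo sapiens) for antiproliferative activity, read by sulforhodamine B assay; a higher number here means a weaker inhibitor of growth, a lower number a stronger inhibitor of growth:
- compound 1, `O=C(Nc1cccc([N+](=O)[O-])c1)Nc1nc2ccc(Cl)cc2s1`: 0.82 ug/mL
- compound 2, `O=C(Nc1nc2ccc([N+](=O)[O-])cc2s1)c1ccc(C(F)(F)F)cc1`: 1.89 ug/mL
- compound 3, `COc1cccc2sc(NC(=O)c3ccc(C(F)(F)F)cc3)nc12`: > 10 ug/mL

Compound 3 stands apart from the other two: its reading is not a number but a limit of the assay, and it sits at the limit of > 10 ug/mL in this assay, at which 1 of the 3 values shown sits. Compound 1 and compound 2 both give numbers within the measurable range, while compound 3 does not, so nothing more than its limit is known about it.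

Compound 4, `COc1cccc2sc(NC(=O)c3ccc([N+](=O)[O-])cc3)nc12`, is not yet measured. It differs from compound 3 in one place: nitro in place of trifluoromethyl on an aromatic carbon, in words, nitro in place of trifluoromethyl on an aromatic carbon. For the measured compounds named here, no pair of measured compounds here differs by this same change, so no measured step tells how large the effect is. Going by the values given here, the only two compounds that carry a number, compound 1 and compound 2, differ from compound 3 in other ways as well, and their values do not isolate this change.

With compound 3 known only as a limit, the step from compound 3 to compound 4 is expected to be modest, and the expected step is an at least 1.2-fold lower number from compound 3 to compound 4 (0.09 log units; that floor lies within the scatter). Compound 4 is estimated at 8 ug/mL, with a range from 2.5 ug/mL to 25 ug/mL, and it may well again give only a limit.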

Compound 4, concentration for 50% growth inhibition: > 10 ug/mL
Compound 4: a limit, no number; the forecaster's own chance of this, stated with the estimate: 45%; middle value at least 1.2-fold (0.09 log units) from the limit.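

Compound 3 and compound 4 both give only a limit of the assay, not a number, so no step can be read for nitro in place of trifluoromethyl: the limit of > 10 ug/mL in this assay, at which 2 of the 4 values shown sit.

The compounds shown leave open whether this change alters growth inhibition at all, and by how much.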